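Para-substituent swap on the anilino series: methoxy for chloro

The compounds below may be only part of what the source reports. "The series", "measured", "known", "first", "only" and "open" are said of these compounds alone.

Working notes. The shared core carries an anilino group in compounds 2 and 3, an isopentylamino group in compound 1. In a functional assay on MGC-803 cells (Homo sapiens) for inhibition, read by MTT assay, with a stated time of 72 h (on this read-out lower numbers stand for stronger inhibition and higher numbers for weaker inhibition), compound 1 `C#CCSc1nc(NCCC(C)C)c2ccncc2n1` reaches only a limit, > 80000 nM, as noted in the limit of > 80000 nM in this assay, at which 1 of the 3 values shown sits. Compound 2 `C#CCSc1nc(Nc2ccc(F)cc2)c2ccncc2n1` gives 15800 nM and compound 3 `C#CCSc1nc(Nc2ccc(Cl)cc2)c2ccncc2n1` gives 16400 nM; the two numbers sit together, a 1.0-fold higher number from compound 2 to compound 3 (0.02 log units; within the scatter), so no order between them is claimed. Moving to compound 4 `C#CCSc1nc(Nc2ccc(OC)cc2)c2ccncc2n1` brings (methoxy in place of chloro on an aromatic carbon). Going by the values given here, the only step that bears on this change is the halogen swap, a 1.0-fold higher number from compound 2 to compound 3 (0.02 log units; within the scatter), which stayed within the scatter; the isopentyl-to-aryl steps an at least 5.0-fold lower number from compound 1 to compound 2 (0.70 log units; beyond the scatter) and an at least 4.8-fold lower number from compound 1 to compound 3 (0.68 log units; beyond the scatter) concern the amine, not the ring substituent. The expected step of a 1.0-fold lower number from compound 3 to compound 4 (0.01 log units; within the scatter) is therefore none beyond the scatter in this assay. Compound 4 is estimated at 16000 nM, within 6000 nM to 45000 nM.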

Compound 4, half-maximal inhibitory concentration: > 80000 nM
Compound 4 ended at the assay's limit; the forecaster's own chance of this, stated with the estimate: 15%; middle value at least 5.0-fold (0.69 log units) away from the limit.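

In this assay, the substituent para to a large group matters in a way the halogen swap did not reveal: methoxy in place of chloro gives an at least 4.8-fold higher number from compound 3 to compound 4 (0.68 log units; beyond the scatter), and methoxy in place of fluoro gives an at least 5.0-fold higher number from compound 2 to compound 4 (0.70 log units; beyond the scatter). One change on the aromatic carbon thus takes the anilino series to the same limit as compound 1: the limit of > 80000 nM in this assay, at which 2 of the 4 values shown sit.

From the compounds shown here alone, since compound 4 stands at a limit, the true size of both steps stays open. Also open, going by these compounds, is how a hydroxyl, an amine or a longer alkoxy chain would read at this place.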